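The compounds below may be only part of what the source reports. "The series", "measured", "known", "first", "only" and "open" are said of these compounds alone.

Three compounds share one core and differ only in the aromatic group on a double-bonded chain carbon bound to a double-bonded chain carbon and a saturated chain carbon. Compound 1 `CC/C(=C(/c1ccc(/C=C/C(=O)O)cc1)c1cc2ccccc2[nH]1)c1ccc(C(F)(F)F)cc1` carries 4-(trifluoromethyl)phenyl there, compound 2 `CC/C(=C(/c1ccc(/C=C/C(=O)O)cc1)c1cc2ccccc2[nH]1)c1ccc(F)cc1Cl` carries 2-chloro-4-fluorophenyl, and compound 3 `CC/C(=C(/c1ccc(/C=C/C(=O)O)cc1)c1cc2ccccc2[nH]1)c1cc(Cl)ccc1Cl` carries 2,5-dichlorophenyl. In a functional assay on MCF7 cells (Homo sapiens) for inhibition (a higher number here means a weaker inhibitor, a lower number a stronger inhibitor), compound 1 gives 139 nM, compound 2 gives 39 nM, and compound 3 gives 71 nM. Compound 3 thus has the second highest of the three numbers, and its distance to each neighbour is small: there is a 2.0-fold lower number from compound 1 to compound 3 (0.29 log units; within the scatter) and a 1.8-fold higher number from compound 2 to compound 3 (0.26 log units; within the scatter), both within the usual scatter. Among the compounds with values here, the only step that clearly stands out is a 3.6-fold lower number from compound 1 to compound 2 (0.55 log units; beyond the scatter).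

Compound 4 `CC/C(=C(/c1ccc(/C=C/C(=O)O)cc1)c1cc2ccccc2[nH]1)c1c(C)cccc1Cl` is the next variation at the same place: 2-chloro-6-methylphenyl in place of 2,5-dichlorophenyl on a double-bonded chain carbon bound to a double-bonded chain carbon and a saturated chain carbon. The two exchanges of this ring that end at compound 3 stayed within the scatter, so a single further exchange of substituents on the same ring is expected to move the number little, if at all. For compound 4 in this assay the estimate is 80 nM, with a likely range from 30 nM to 220 nM, which amounts to an expected step of a 1.1-fold higher number from compound 3 to compound 4 (0.05 log units; within the scatter).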

Compound 4, half-maximal inhibitory concentration: 30 nM
The estimate for compound 4 lay 2.7-fold (0.43 log units) above the measured number; the range from low to high includes it.
By their numbers in this assay, from the lowest: compounds 4, 2, 3 and 1 (each within the scatter of the next, the first and the last beyond it).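

Exchanging 2,5-dichlorophenyl for 2-chloro-6-methylphenyl gives a 2.4-fold lower number from compound 3 to compound 4 (0.37 log units; beyond the scatter) and so moves the number beyond the scatter, the first exchange involving compound 3 to do so, although both groups count 8 heavy atoms and one six-membered aromatic ring. Size counted this way therefore does not settle the outcome at this position, and neither does the mere presence of chlorine: compounds 2, 3 and 4 all carry it, yet compound 3 goes against any simple rule that chlorine-bearing rings sit together, while a 1.3-fold lower number from compound 2 to compound 4 (0.11 log units; within the scatter) shows that compound 2 and compound 4 cannot be told apart, and a 4.6-fold lower number from compound 1 to compound 4 (0.67 log units; beyond the scatter) is the largest step in this set. Nothing available gives a reason for these differences.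

The compounds shown cannot separate what the methyl group contributes from what the chlorine contributes, since no ring here carries a single chlorine or a single methyl group alone. They also leave open how this position would respond to a ring bearing an amine or a carboxylic acid, or to a longer chain in place of the methyl group.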